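Replacing a bromo-methoxyphenyl ring by a tert-butylphenyl ring

The compounds below may be only part of what the source reports. "The series", "measured", "known", "first", "only" and "open" are said of these compounds alone.

Compound 2, `COc1cc(NC(=O)Nc2cc(Nc3ccc(Br)cc3OC)ncn2)cc(OC)c1`, is the reference point here. In a functional assay on HCC827 cells (Homo sapiens) for inhibition, read by MTT assay, with a stated time of 48 h, tested at 10 uM (on this read-out lower numbers stand for less inhibition and higher numbers for more inhibition at the one concentration tested (going by the name of the read-out)), compound 2 gives 57.7%. Within the data shown here, the only other measured compound, compound 1, `COc1cc(NC(=O)Nc2cc(Nc3cccc(C(C)(C)C)c3)ncn2)cc(OC)c1`, gives 48.7% in this assay; the gap between the two values lies within the scatter of this kind of measurement, so the two compounds cannot be told apart on these numbers.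

Compound 3, `COc1cc(NC(=O)Nc2cc(Nc3ccc(C(C)(C)C)cc3)ncn2)cc(OC)c1`, has not yet been measured in this assay. It differs from compound 2 in one place: 4-(tert-butyl)phenyl in place of 4-bromo-2-methoxyphenyl on a nitrogen on an aromatic ring.

Among the measured compounds shown here, the one measured step that bears on this change is a number 9 percentage points higher from compound 1 to compound 2 (within the scatter), which exchanged a tert-butyl-bearing ring for the bromo-methoxy ring without moving the read-out beyond the scatter. Compound 3 brings a tert-butyl-bearing ring back, so no step beyond the scatter is expected in this assay. For compound 3 the expected step is therefore a number 6.7 percentage points lower from compound 2 to compound 3 (within the scatter). Compound 3 is estimated to give 51%, with a range from 36% to 66%.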

Compound 3, a percentage reported as inhibition, at one concentration (the size of the read-out at that concentration, not a potency): 32.7%
Beside the measured number, compound 3's estimate is 18.3 percentage points above it, outside the stated range (below it).
By their numbers in this assay, from the lowest: compound 3; then compounds 1 and 2 (each within the scatter of the next).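

In this assay, the ring on the nitrogen now proves able to move the read-out: the change gives a number 25 percentage points lower from compound 2 to compound 3 (beyond the scatter), a step beyond the scatter, which the earlier pair had not shown. The tert-butyl group does not fix the read-out by its presence alone, as moving from 3-(tert-butyl)phenyl to 4-(tert-butyl)phenyl gives a number 16 percentage points lower from compound 1 to compound 3 (beyond the scatter), also beyond the scatter. Among these compounds, the place of the tert-butyl group on the ring therefore matters. No measurement shown here explains either step.

The compounds shown leave open whether the bromine or the methoxy group of compound 2 accounts for its difference from compound 3, as both leave in one change. As far as these compounds go, how a phenyl ring carrying only one of them, or a morpholine ring, would read at this position also remains open.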